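The source may report more compounds than this note shows. Statements on the series, on what has been measured and on what is new or still open speak of the compounds shown alone.

Measured so far in a functional assay on MT4 cells (Homo sapiens) for cytotoxicity (a higher number here means a weaker inhibitor, a lower number a stronger inhibitor), are these two compounds:

compound 1 `Cc1cc(Cl)cc(Sc2cccc(N)c2C#N)c1` gives 16000 nM as a number
compound 2 `COc1ccccc1[S+]([O-])c1cccc(N)c1C#N` gives > 200000 nM as a limit

Compound 2 rests at > 200000 nM in this assay as a limit of the assay and not as a number. Compound 3 `Cc1ccccc1[S+]([O-])c1cccc(N)c1C#N` departs from compound 2 in one place, and the change methyl in place of methoxy on an aromatic carbon puts methyl in place of methoxy on an aromatic carbon, ortho to a large group. Among the compounds with values here, no measured pair here shows such an exchange, so its size has to be judged from the standing of compound 2 alone. Within the data shown here, the only numeric reading comes from compound 1 at 16000 nM in this assay and that compound differs from compound 2 in more than one place. A small move toward a lower number is expected, and the reading may well stay a limit. The estimated change runs an at least 1.2-fold lower number from compound 2 to compound 3 (0.09 log units; that floor lies within the scatter) in this reckoning. Compound 3 is estimated at 160000 nM within an expected range of 60000 nM to 250000 nM in this assay once it is measured.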

Compound 3, half-maximal inhibitory concentration: > 200000 nM
Compound 3: only a limit was reported; the forecaster's own chance of this, stated with the estimate: 60%; middle value at least 1.2-fold (0.09 log units) away from the limit.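

In this assay, compound 2 and compound 3 are both reported only as limits of the assay and not as numbers, and no step between them can be read: the limit of > 200000 nM in this assay, at which 2 of the 3 values shown sit.

The compounds shown leave open what size, if any, the exchange of methoxy for methyl has in this assay.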